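This account rests on a few compounds, and the source may have more. Where it says the series, first, only, none or still open, it means among the compounds named here.

Compound 2 `COc1cccc(CN(CCCN2CCCC2)c2cc(-c3ccccc3)no2)c1` carries the only number shown in a functional assay for antagonist activity at proteinase-activated receptor 1 (Homo sapiens); on this read-out higher numbers stand for weaker inhibition and lower numbers for stronger inhibition: in this assay compound 2 gives 3300 nM. Compound 1 `COc1cccc(CN(CCCN2CCC2)c2cc(-c3ccccc3)no2)c1` stops at a limit of the assay, giving > 10000 nM in this assay. Going by the values given here, the one measured step, an at least 3.0-fold lower number from compound 1 to compound 2 (0.48 log units; beyond the scatter), is bounded by that limit (the limit of > 10000 nM in this assay, at which 1 of the 2 values shown sits). Compound 3 `COc1cccc(CN(CCCN2/C=C\C=C/C=C\C2)c2cc(-c3ccccc3)no2)c1` differs from compound 2 by a group of 8 heavy atoms (7 carbon, 1 nitrogen; one eight-membered non-aromatic ring with 1 hetero atom) in place of a group of 5 heavy atoms (4 carbon, 1 nitrogen; one five-membered non-aromatic ring with 1 hetero atom), on a saturated chain carbon, three bonds along the chain from a nitrogen on an aromatic ring. Among the compounds with values here, the only step bearing on it is an at least 3.0-fold lower number from compound 1 to compound 2 (0.48 log units; beyond the scatter), where the larger ring lowered the number; a still larger ring is expected to give compound 3 a step of a 2.2-fold lower number from compound 2 to compound 3 (0.34 log units; beyond the scatter). For compound 3 the estimate in this assay is 1500 nM, between 400 nM and 6000 nM.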

Compound 3, half-maximal inhibitory concentration: > 10000 nM
Compound 3 ended at the assay's limit; the forecaster's own chance of this, stated with the estimate: 10%; middle value at least 6.6-fold (0.82 log units) from the limit.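

The lower number seen on going from azetidin-1-yl to pyrrolidin-1-yl does not carry on to the eight-membered ring: this assay shows an at least 3.0-fold higher number from compound 2 to compound 3 (0.48 log units; beyond the scatter). The step from compound 1 to compound 3 cannot be read; both values are limits. Of the three rings at this place, only the pyrrolidin-1-yl of compound 2 gives a number, while the smaller and the larger ring both end at the same limit: the limit of > 10000 nM in this assay, at which 2 of the 3 values shown sit. On these data alone, whether piperidin-1-yl, a six-membered ring, would keep the number of compound 2 stays open. The compounds shown also do not separate the size of the eight-membered ring from its three double bonds.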